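From a propyl to a 2-(pyrrolidin-1-yl)ethyl side chain

The source may hold more compounds than are shown below. What is called first, only, known or untested is meant among the compounds shown, and "the series" means these compounds.

Of the compounds shown here, three sharing one core have been measured in a functional assay on OVCAR-8 cells (Homo sapiens) for antiproliferative activity; on this read-out lower numbers stand for stronger inhibition and higher numbers for weaker inhibition. Compound 1 (`Cn1ncc(Cl)c1-c1cc(C(=O)N[C@@H]2CN[C@H](CCN3CCC(O)CC3)C[C@H]2c2ccc(Cl)c(Cl)c2)oc1Cl`) gives 15900 nM, compound 2 (`Cn1ncc(Cl)c1-c1cc(C(=O)N[C@@H]2CN[C@H](CC(N)=O)C[C@H]2c2ccc(Cl)c(Cl)c2)oc1Cl`) gives 1000 nM, and compound 3 (`CCC[C@@H]1C[C@@H](c2ccc(Cl)c(Cl)c2)[C@H](NC(=O)c2cc(-c3c(Cl)cnn3C)c(Cl)o2)CN1`) gives 1620 nM. Compound 3 therefore belongs to the low pair of the three numbers. The highest number stands well apart, a 9.8-fold lower number from compound 1 to compound 3 (0.99 log units; beyond the scatter), while the other two cannot be told apart, a 1.6-fold higher number from compound 2 to compound 3 (0.21 log units; within the scatter).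

Compound 4 (`Cn1ncc(Cl)c1-c1cc(C(=O)N[C@@H]2CN[C@H](CCN3CCCC3)C[C@H]2c2ccc(Cl)c(Cl)c2)oc1Cl`) differs from compound 3 in one place: pyrrolidin-1-yl in place of methyl on a saturated chain carbon, two bonds along the chain from a saturated ring carbon. This is pyrrolidin-1-yl in place of methyl on a saturated chain carbon, two bonds along the chain from a saturated ring carbon, so propyl becomes 2-(pyrrolidin-1-yl)ethyl.

Within the data shown here, the closest precedent is the measured step at that same place, a 9.8-fold lower number from compound 1 to compound 3 (0.99 log units; beyond the scatter), where methyl stands in place of 4-hydroxypiperidin-1-yl. A second step, a 16-fold lower number from compound 1 to compound 2 (1.20 log units; beyond the scatter), also leads away from that one ring-ended side chain. Pyrrolidin-1-yl itself has not been measured, and compound 1 is the only ring-ended example, so only part of that gap is expected to return, towards weaker inhibition. The expected step is a 3.1-fold higher number from compound 3 to compound 4 (0.49 log units; beyond the scatter). Compound 4 is estimated at 5000 nM, with an expected range of 1500 nM to 16000 nM.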

Compound 4, half-maximal inhibitory concentration: 1840 nM
Compound 4: middle estimate off by 2.7-fold (0.43 log units), on the high side; the range from low to high includes it.
By their numbers in this assay, from the lowest: compounds 2, 3 and 4 (each within the scatter of the next); then compound 1.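

In this assay a ring at the end of this side chain does not by itself bring the high number seen for compound 1, since pyrrolidin-1-yl in place of methyl gives a 1.1-fold higher number from compound 3 to compound 4 (0.06 log units; within the scatter) and (pyrrolidin-1-yl)methyl in place of carbamoyl gives a 1.8-fold higher number from compound 2 to compound 4 (0.26 log units; within the scatter) and neither step can be told from scatter. The contrast now lies between the two ring-ended chains, with pyrrolidin-1-yl in place of 4-hydroxypiperidin-1-yl giving an 8.6-fold lower number from compound 1 to compound 4 (0.94 log units; beyond the scatter) and leaving compound 1 as the lone exception to a flat picture in which compounds 2, 3 and 4 cannot be separated. Nothing available on these compounds offers an explanation for that contrast.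

On these data alone, it remains open whether the high number of compound 1 goes with the hydroxyl or with the piperidine ring, which a plain piperidin-1-yl on the same chain would help to separate. As far as these compounds go, it is also open whether a primary amine, a carboxylic acid or a longer chain at this place would stay level with compounds 2, 3 and 4.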